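The compounds below may be only part of what the source reports. "The series", "measured", "known", "first", "only" and "open" are said of these compounds alone.

Measured compounds:
Compound 1, `Cc1cccc(-c2noc(C3CC(=O)N(c4ccc(C)c(Cl)c4)C3)n2)c1`: 240 nM in an in vitro functional assay on HEK293-A cells for positive allosteric modulation of metabotropic glutamate receptor 5 (Homo sapiens), read by FLIPR and calcium flux; a lower number here means that less compound is needed, a higher number that more compound is needed for the effect
Compound 2, `COc1cccc(-c2noc(C3CC(=O)N(c4ccc(Cl)cc4)C3)n2)c1`: 4800 nM in this assay
Compound 3, `O=C1CC(c2nc(-c3ccccc3)no2)CN1c1ccccc1`: 350 nM in this assay

Of the compounds shown here, three share a core and have been measured in this assay. Compound 3 gives the second highest of the three numbers. Its nearest neighbour is compound 1, whose number is lower, but the gap between them falls within the usual scatter of repeated measurements, so the two cannot be told apart. Compound 2, the furthest from compound 3, sits well beyond the scatter, with a clearly higher number.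

Compound 4, `O=C1CC(c2nc(-c3ccccc3)no2)CN1c1ccc(F)cc1`, has not yet been measured. It differs from compound 3 in one place: fluoro in place of hydrogen on an aromatic carbon. Among the compounds with values here, no pair of measured compounds differs by just this change, so there is no directly comparable step to lean on. Compound 1 and compound 2 both carry substituents on the same ring, yet they lie on opposite sides of compound 3, which gives no clear direction.

Compound 4 is therefore expected to land close to compound 3, with a step from a 1.2-fold lower number from compound 3 to compound 4 (0.07 log units; within the scatter) that is not expected to exceed the scatter in either direction. The estimate for compound 4 in this assay is 300 nM, within a range from 100 nM to 900 nM.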

Compound 4, half-maximal effective concentration: 58 nM
For compound 4 the middle estimate is 5.2-fold (0.71 log units) above the measured one, and the stated range ends above it.
By their numbers in this assay, from the lowest: compound 4; then compounds 1 and 3 (each within the scatter of the next); then compound 2.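

Fluoro in place of hydrogen on an aromatic carbon, para to a large group, is the first change here that can be read alone, since compound 1 and compound 2 each differ from compound 3 in more than one place. In this assay this change gives a 6.0-fold lower number from compound 3 to compound 4 (0.78 log units; beyond the scatter), a step beyond the usual scatter, so going from phenyl to 4-fluorophenyl at this place is enough on its own to alter how much compound is needed for the effect. No measurement offered here bears on why one fluorine atom has an effect of this size.

Within the data shown here, with only this one change at this place, it remains open whether the lower number is particular to fluoro or would also come with a group such as nitrile, trifluoromethyl or an amine in the same spot. On these data alone, it is equally open whether fluoro elsewhere on this ring, or the same change made on a compound with a different group on the other side of the shared core, would give a step of similar size.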